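Working notes: from compound 2 to compound 3

A few compounds are considered here, and "the series" means these few. Any claim that something is new, unique, unknown or untested is made for them only; others in the source may bear on it.

In a functional assay on U-87MG ATCC cells for inhibition, with U-87 MG (Homo sapiens) as the target, read by MTT assay, with a stated time of 72 h (on this read-out higher numbers stand for weaker inhibition and lower numbers for stronger inhibition), compound 1 `Oc1c(C(Nc2ccccn2)c2ccccc2Cl)ccc2cccnc12` gives 9400 nM and compound 2 `Cc1cc(C)c(C(Nc2ccccn2)c2ccc3cccnc3c2O)c(C)c1` gives 10000 nM. These two values lie within the scatter of each other, so compound 2 holds no separate rank. The next compound is compound 3 `CCc1ccc(C(Nc2ccccn2)c2ccc3cccnc3c2O)cc1`, with this change: 4-ethylphenyl in place of 2,4,6-trimethylphenyl on a saturated chain carbon bound to an aromatic carbon and a nitrogen on an aromatic ring. It places 4-ethylphenyl in place of 2,4,6-trimethylphenyl on a saturated chain carbon bound to an aromatic carbon and a nitrogen on an aromatic ring. For the measured compounds named here, only one measured step bears on this place: a 1.1-fold higher number from compound 1 to compound 2 (0.03 log units; within the scatter). This step, 2,4,6-trimethylphenyl in place of 2-chlorophenyl, stays within the scatter. Going by the values given here, it is thin evidence, as no measured compound carries 4-ethylphenyl. No change beyond the scatter is therefore expected in this assay. The expected step is a 1.3-fold lower number from compound 2 to compound 3 (0.10 log units; within the scatter). For compound 3 the estimated value is 8000 nM, with an expected range of 3000 nM to 20000 nM.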

Compound 3, half-maximal inhibitory concentration: 9300 nM
The estimate for compound 3 lay 1.2-fold (0.07 log units) below the measured number, and the stated range covers the measured number.
By their numbers in this assay, from the lowest: compounds 3, 1 and 2 (each within the scatter of the next).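

In this assay the change to 4-ethylphenyl gives a 1.1-fold lower number from compound 2 to compound 3 (0.03 log units; within the scatter) and a 1.0-fold lower number from compound 1 to compound 3 (0.00 log units; within the scatter) and so adds a third group to this place on a saturated chain carbon bound to an aromatic carbon and a nitrogen on an aromatic ring. With 2-chlorophenyl, 2,4,6-trimethylphenyl and 4-ethylphenyl all within the scatter of one another, no group shown at this place stands apart from the others in this read-out, which a single earlier step could not establish across three groups. Nothing available explains why the three values stay together. 

On these data alone, what an amine or a carboxylic acid on the phenyl ring would do remains open, as does a saturated chain such as hexyl in place of the ring. Changes elsewhere on the shared core are also open, since the three compounds shown differ only at this place.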